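A few compounds are considered here, and "the series" means these few. Any claim that something is new, unique, unknown or untested is made for them only; others in the source may bear on it.

Measured compounds:
compound 1 `Cc1cc(NC(=O)Cn2nnc(-c3ccccc3)n2)n(C2CCC(C)(C)CC2)n1`
compound 2 `Cc1cc(NC(=O)Cn2nnc(-c3ccccc3)n2)n(C2CC2)n1`
compound 3 `Cc1cc(NC(=O)Cn2nnc(-c3ccccc3)n2)n(C2CCCC2)n1`

In an assay on HEK293 cells for activation of Kir3.1/Kir3.2 (Homo sapiens), read by thallium flux (a lower number here means that less compound is needed, a higher number that more compound is needed for the effect), compound 1 gives > 221 nM, which is a limit of the assay and not a number. Compound 2 gives > 5000 nM, again only a limit. Among the compounds with values here, compound 3 gives 163 nM, the single plain number among the three. Compound 4 `Cc1cc(NC(=O)Cn2nnc(-c3ccccc3)n2)n(CC2CCCCC2)n1` has not been measured; it differs from compound 3 by cyclohexylmethyl in place of cyclopentyl on an aromatic nitrogen. Two measured steps at this position bear on the change: the step of an at least 30-fold lower number from compound 2 to compound 3 (1.48 log units; beyond the scatter) was large, whereas the step of an at least 1.3-fold lower number from compound 1 to compound 3 (0.13 log units; that floor lies within the scatter) stays within the scatter, its size capped by the limit (the limit of > 221 nM in this assay, at which 1 of the 3 values shown sits). For compound 4 a step within the scatter, or a modest rise, is expected: a 1.8-fold higher number from compound 3 to compound 4 (0.26 log units; within the scatter). Compound 4 is estimated at 300 nM, between 100 nM and 1200 nM.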

Compound 4, half-maximal effective concentration: 176 nM
The estimate for compound 4 lay 1.7-fold (0.23 log units) above the measured number; measured number inside the range.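

Moving the ring one carbon away from the aromatic nitrogen, with cyclohexylmethyl in place of cyclopentyl, gives a 1.1-fold higher number from compound 3 to compound 4 (0.03 log units; within the scatter), so this larger group fits this position as well as cyclopentyl does. Cyclohexylmethyl also stands well apart from cyclopropyl, with an at least 28-fold lower number from compound 2 to compound 4 (1.45 log units; beyond the scatter), while the comparison with 4,4-dimethylcyclohexyl gives only an at least 1.2-fold lower number from compound 1 to compound 4 (0.09 log units; that floor lies within the scatter). Compound 1 and compound 2 each carry a limit of the assay, so both steps are floors rather than exact sizes. Going by these compounds, whether this position needs a ring at all remains open: an unbranched butyl chain would test that. How a piperidine ring bearing an amine or a carboxylic acid would behave here is also unknown.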